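An Imidazole for an Imidazoline, Tried on a Second Core

This account rests on a few compounds, and the source may have more. Where it says the series, first, only, none or still open, it means among the compounds named here.

Compound 1 `c1ccc(-c2cnco2)c(NCC2=NCCN2)c1` and compound 2 `c1ccc(-c2cnco2)c(NCc2c[nH]cn2)c1` share one core and differ in a single place. In a functional assay for activation of Alpha-1A adrenergic receptor (Homo sapiens) (a higher number here means that more compound is needed for the effect, a lower number that less compound is needed), compound 1 gives 20 nM. In this assay compound 2 gives 50.1 nM. The change between these two is a group of 5 heavy atoms (3 carbon, 2 nitrogen; one five-membered aromatic ring with 2 hetero atoms) in place of a group of 5 heavy atoms (3 carbon, 2 nitrogen; one five-membered non-aromatic ring with 2 hetero atoms), on a saturated chain carbon bound to a nitrogen on an aromatic ring, and in this assay it made a 2.5-fold higher number from compound 1 to compound 2 (0.40 log units; beyond the scatter).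

Compound 3 `CCN(CC)C(=O)c1ccccc1OCC1=NCCN1` is built on a different core; how the two cores differ is not broken down here. In this assay compound 3 gives only a limit, < 100000 nM. That is the limit of < 100000 nM in this assay, at which 1 of the 3 values shown sits.

Compound 4 `CCN(CC)C(=O)c1ccccc1OCc1c[nH]cn1` has not yet been measured. It stands to compound 3 as compound 2 stands to compound 1: a group of 5 heavy atoms (3 carbon, 2 nitrogen; one five-membered aromatic ring with 2 hetero atoms) in place of a group of 5 heavy atoms (3 carbon, 2 nitrogen; one five-membered non-aromatic ring with 2 hetero atoms), on a saturated chain carbon bound to an oxygen on an aromatic ring. The surroundings are not the same word for word: in the first pair the saturated chain carbon is bound to a nitrogen on an aromatic ring, in the second pair to an oxygen on an aromatic ring, so this is the same kind of change rather than the same change. Among the compounds shown it occurs twice in all.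

The expectation for compound 4 rests on compound 1 and compound 2, whose step was a 2.5-fold higher number from compound 1 to compound 2 (0.40 log units; beyond the scatter). It also rests on compound 3 giving only a limit rather than a number. The step expected from that limit is a step that the limit leaves unreadable from compound 3 to compound 4. Compound 4 is expected to give about 40000 nM in this assay, somewhere between 4000 nM and 200000 nM, with a real chance that only a limit is reported again.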

Compound 4, half-maximal effective concentration: < 100000 nM
Compound 4: no number, only a limit (the forecaster's own chance of this, stated with the estimate: 50%); the middle value does not contradict the limit.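

In this assay compound 4 gives only a limit, < 100000 nM, and compound 3 is likewise reported only as a limit, so no step can be read between compound 3 and compound 4; both stand at the same boundary: the limit of < 100000 nM in this assay, at which 2 of the 4 values shown sit.

The compounds shown leave open whether the 1H-imidazol-4-yl group changes activation on the core of compound 3 at all, and whether the step seen on the core of compound 1 carries over to it.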